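The compounds below may be only part of what the source reports. "The series", "measured", "known", "first", "only" and "open" are said of these compounds alone.

Measured so far:
- compound 1, `COc1ccc(C2N=C(SCc3ccc(Cl)cc3)NC(C)=C2C(=O)Nc2ccc(F)cc2)cc1OC`: 15.5%
- compound 2, `CC1=C(C(=O)Nc2ccc(Br)cc2)C(c2ccc(Cl)cc2Cl)N=C(SCc2ccccc2Cl)N1`: 16%

Both numbers come from a functional assay on the whole organism (artery, strain albino) with Rattus norvegicus as the target, with a stated time of 120 min, at a dose of 10 mg/kg by the oral route; a higher number here means more inhibition at the dose given (going by the name of the read-out), a lower number less inhibition. In this assay compound 1 gives 15.5% and compound 2 gives 16%. The two values differ by an amount that lies within the usual scatter of such measurements, so compound 2 stands level with compound 1 and neither can be placed above the other. For the measured compounds named here, no pair of compounds that differ in only one place has been measured, so no step size is known from the data.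

Compound 3, `CC1=C(C(=O)Nc2ccc(Br)cc2)C(c2ccc(Cl)cc2Cl)N=C(SCc2ccc(Cl)cc2)N1`, has not yet been tested in this assay. It shares the core of compound 2, and the change is 4-chlorophenyl in place of 2-chlorophenyl on a saturated chain carbon bound to a sulfur. Going by the values given here, with no measured step to lean on, the expectation for the step from compound 2 to compound 3 is no change beyond the scatter, so no change at the digits printed from compound 2 to compound 3 (within the scatter) is estimated to be small in either direction. Compound 3 is therefore expected to give about 16%, likely between 5% and 28%.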

Compound 3, a percentage reported as inhibition, in the whole organism at one dose (the size of the read-out at that dose, not a potency): 17.5%
Estimate against measurement, compound 3: 1.5 percentage points below; low and high end bracket the measured number.
By their numbers in this assay, from the lowest: compounds 1, 2 and 3 (each within the scatter of the next).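

In this assay, for the compounds shown here, the swap of 2-chlorophenyl for 4-chlorophenyl, on the saturated chain carbon bound to the sulfur, gives a number 1.5 percentage points higher from compound 2 to compound 3 (within the scatter) and is the first step read between two compounds that differ in only one place. The two compounds carry the same atoms joined differently, and at this single oral dose they cannot be told apart, so this one swap on this core has no effect that the measurement can separate from ordinary scatter. No independent measurement bears on this result, so the data offer no explanation for it.

The compounds shown leave open whether anything placed on this chain carbon can move the number beyond the scatter, since both groups compared here are chlorophenyl rings, and a plain phenyl, a carboxylic acid, an amine or a longer chain ending in a ring would test far more than the swap seen here. They also leave open whether the same swap would remain as small with a different group on the amide or on the core.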